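A Bromo Group Added to the Phenyl Ring

A few compounds are considered here, and "the series" means these few. Any claim that something is new, unique, unknown or untested is made for them only; others in the source may bear on it.

Compound 1 `O=C(Nc1ccc(Oc2ccnc3[nH]ccc23)cc1)c1cc2cccnc2n(-c2ccccc2)c1=O` and compound 2 `O=C(Nc1ccc(Oc2ccnc3[nH]ccc23)c(F)c1)c1cc2cccnc2n(-c2ccccc2)c1=O` share one core and differ only in one place. In a functional assay on NCI-H460 cells (Homo sapiens) for antiproliferative activity, read by MTT assay, with a stated time of 72 h (on this read-out higher numbers stand for weaker inhibition and lower numbers for stronger inhibition), compound 1 gives 380 nM, while compound 2 gives 180 nM. The step of a 2.1-fold lower number from compound 1 to compound 2 (0.32 log units; beyond the scatter) lies beyond the scatter but is modest in size. Among the two numbers measured so far compound 2 stands lowest, and its nearest neighbour is compound 1.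

Compound 3 `O=C(Nc1ccc(Oc2ccnc3[nH]ccc23)c(F)c1)c1cc2cccnc2n(-c2ccc(Br)cc2)c1=O` is not yet measured. It differs from compound 2 by bromo in place of hydrogen on an aromatic carbon. Among the compounds with values here, no measured step concerns this part of the core: the only step available, a 2.1-fold lower number from compound 1 to compound 2 (0.32 log units; beyond the scatter), changes a different position, so it gives no direct guide to the effect of the bromo group. With nothing to point in either direction, the step of no change at the digits printed from compound 2 to compound 3 (within the scatter) is expected to stay within the scatter.

Compound 3 is therefore estimated to give 180 nM in this assay, with a range from 80 nM to 400 nM that allows for a small shift either way.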

Compound 3, half-maximal inhibitory concentration: 260 nM
Compound 3: the middle estimate sits 1.4-fold (0.16 log units) below what was measured; the measured number falls inside the stated range.
By their numbers in this assay, from the lowest: compounds 2, 3 and 1 (each within the scatter of the next, the first and the last beyond it).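

In this assay, the change from phenyl to 4-bromophenyl gives a 1.4-fold higher number from compound 2 to compound 3 (0.16 log units; within the scatter) and so cannot be told apart from repeat-to-repeat variation, which means that this carbon of the six-membered aromatic ring, para to a large group, accepts a bromo group with no readable effect on the antiproliferative number. Within the data shown here, this is the first information about this part of the molecule, since the earlier step, a 2.1-fold lower number from compound 1 to compound 2 (0.32 log units; beyond the scatter), concerns a fluoro group at a different place and says nothing about this ring. No further data bear on this result, so the reason for it stays unknown.

A single bromo group says little about the position as a whole, and the compounds shown leave open whether an amine, a carboxylic acid or a longer chain at the same carbon would leave the number just as it is or move it beyond the scatter. Also open, going by these compounds, is whether the bromo group would have the same small effect on compound 1, which lacks the fluoro group.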